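The source may hold more compounds than are shown below. What is called first, only, known or untested is meant among the compounds shown, and "the series" means these compounds.

Compound 1 (`COc1ccc(C(=O)CSc2nc(Cc3c(Cl)cccc3Cl)cc(=O)[nH]2)cc1`), compound 2 (`Cc1c(Cc2c(Cl)cccc2Cl)nc(SCC(=O)c2ccccc2)[nH]c1=O`) and compound 3 (`Cc1c(Cc2c(Cl)cccc2Cl)nc(SCC(=O)c2ccc(F)cc2)[nH]c1=O`) have all been tested in an ADME assay on MT4 cells (Homo sapiens) for cytotoxicity, read by MTT assay; on this read-out lower numbers stand for higher toxicity in this test and higher numbers for lower toxicity in this test. Compound 1 gives > 11000 nM, which is a limit. Compound 2 gives > 60000 nM, which is also a limit. Compound 3 gives > 57000 nM, again a limit, so it has no exact place on the scale, and neither do the other two.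

Compound 4 (`COc1ccc(C(=O)CSc2nc(Cc3c(Cl)cccc3Cl)c(C)c(=O)[nH]2)cc1`) differs from compound 3 in one place: methoxy in place of fluoro on an aromatic carbon. This puts methoxy in place of fluoro on an aromatic carbon, para to a large group. Compound 1 also carries the 4-methoxyphenyl group, but the core of compound 1 differs from that of compound 4.

Among the compounds with values here, the one measured step nearby is a step that the two limits leave unreadable from compound 2 to compound 3, and it offers no size to carry over. With no measured size to go on, no change beyond the scatter is expected in this assay, in either direction. The expected step is an at least 1.4-fold lower number from compound 3 to compound 4 (0.15 log units; that floor lies within the scatter). The estimate for compound 4 is 40000 nM, with an expected range from 10000 nM to 100000 nM.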

Compound 4, half-maximal cytotoxic concentration: > 56000 nM
Compound 4: only a limit was reported (the forecaster's own chance of this, stated with the estimate: 85%); middle value at least 1.4-fold (0.14 log units) away from the limit.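

In this assay, compound 1, compound 2, compound 3 and compound 4 all give limits, so the steps from the first three to compound 4 cannot be read. The compounds shown leave open whether swapping fluoro for methoxy changes the cytotoxic concentration at all.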